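The source may report more compounds than this note shows. Statements on the series, on what has been measured and on what is new or still open speak of the compounds shown alone.

Working notes on the series: two nucleosides have been read so far in a functional assay on HCT-116 cells (Homo sapiens), read by MTT assay, with a stated time of 72 h (on this read-out higher numbers stand for weaker inhibition and lower numbers for stronger inhibition), compound 1 (`Cc1nc(N)c2c(-c3ccccc3)cn([C@@H]3O[C@H](CO)[C@@H](O)[C@H]3O)c2n1`) and compound 2 (`Nc1nc2c(c(-c3ccco3)cn2[C@@H]2O[C@H](CO)[C@@H](O)[C@H]2O)c(=O)[nH]1`). Compound 2 gives > 20000 nM, which is a limit of the assay and not a number, so its position is bounded only on one side. Compound 1 also bears phenyl on its shared-type aromatic carbon and gives > 100000 nM, likewise only a limit.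

Compound 3 (`Nc1nc2c(c(-c3ccccc3)cn2[C@@H]2O[C@H](CO)[C@@H](O)[C@H]2O)c(=O)[nH]1`) has phenyl in place of furan-2-yl on an aromatic carbon of compound 2: phenyl in place of furan-2-yl on an aromatic carbon. Going by the values given here, no measured step is available to size this exchange. With compound 2 at > 20000 nM, a limit, no change beyond the scatter and no particular direction are expected in this assay. The expected step is a step that the limit leaves unreadable from compound 2 to compound 3. For compound 3 the estimate is 25000 nM, with an expected range of 10000 nM to 100000 nM.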

Compound 3, half-maximal inhibitory concentration: > 20000 nM
Compound 3: only a limit was reported; the forecaster's own chance of this, stated with the estimate: 85%; the middle value does not contradict the limit.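

In this assay compound 3 gives > 20000 nM, a limit of the assay and not a number. Going by these compounds alone, compound 2 also stands at a limit, and no step from compound 2 to compound 3 can be read. The compounds shown leave open how phenyl and furan-2-yl compare in this assay.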